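Chloro replaced by methyl in compound 3

The source may report more compounds than this note shows. Statements on the series, on what has been measured and on what is new or still open speak of the compounds shown alone.

In a functional assay on HL-60 cells (Homo sapiens) for cytotoxicity, read by luminescence and CellTiter-Glo, with a stated time of 3 days (on this read-out lower numbers stand for stronger inhibition and higher numbers for weaker inhibition), compound 1 `N#Cc1ccc(NC(=O)c2cccc(Br)c2O)cc1` gives 2910 nM, compound 2 `O=C(Nc1cc(C(F)(F)F)cc(C(F)(F)F)c1)c1ccc(Br)cc1O` gives 270 nM and compound 3 `N#Cc1ccc(NC(=O)c2ccc(Cl)cc2O)cc1` gives 1300 nM. Compound 3 stands second highest of these three numbers, and its gaps to compound 1 and to compound 2 both lie beyond the scatter. Compound 4 `Cc1ccc(C(=O)Nc2ccc(C#N)cc2)c(O)c1` has methyl in place of chloro on an aromatic carbon, meta to a hydroxy group and para to a large group (methyl in place of chloro on an aromatic carbon). Going by the values given here, no measured pair isolates this replacement, so the expectation is tentative. No step beyond the scatter is expected in this assay, with a slight lean toward a higher number. The expected step is a 1.5-fold higher number from compound 3 to compound 4 (0.16 log units; within the scatter). For compound 4 the estimated value is 1900 nM, with an expected range of 700 nM to 4500 nM.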

Compound 4, half-maximal inhibitory concentration: 2420 nM
Estimate against measurement, compound 4: 1.3-fold (0.11 log units) below, within the range that was stated.
By their numbers in this assay, from the lowest: compound 2; then compounds 3, 4 and 1 (each within the scatter of the next, the first and the last beyond it).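

In this assay, going by these compounds alone, methyl in place of chloro on this aromatic carbon, meta to a hydroxy group and para to a large group, gives a 1.9-fold higher number from compound 3 to compound 4 (0.27 log units; within the scatter) and is the first single-place comparison. On this read-out, chloro and methyl are therefore not separated at this position. The measurements shown offer no explanation for this result.

From the compounds shown here alone, whether an amine or a carboxylic acid on this carbon would give a step beyond the scatter remains open. Also open, going by these compounds, is whether methyl in place of chloro would give a similar step with the other amide partner seen in compound 2.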